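The source may hold more compounds than are shown below. What is called first, only, known or untested is meant among the compounds shown, and "the series" means these compounds.

Three compounds share one core and were measured in an ADME assay on the whole organism with Oryza sativa as the target, tested at 0.1 uM; a higher number here means a weaker effect of the compound at the concentration tested, a lower number a stronger effect:

Compound 1 `CCc1ccccc1NC(=O)N[C@@H](C)c1ccccc1` gives 100%.
Compound 2 `CC(C)c1cccc(NC(=O)N[C@H](C)c2ccccc2)c1` gives 74%.
Compound 3 `CC(C)c1cccc(NC(=O)N[C@@H](C)c2ccccc2)c1` gives 95%.

Compound 3 stands second highest of the three numbers; its gap to compound 1 lies within the scatter, while compound 2 sits lower, beyond it. Among the compounds with values here, the only single-place step is a number 21 percentage points higher from compound 2 to compound 3 (beyond the scatter), which rests on (the fact that compounds 2 and 3 differ only in the configuration as drawn). Compound 4 `C[C@H](NC(=O)Nc1cccc(F)c1)c1ccccc1` differs from compound 3 by fluoro in place of isopropyl on an aromatic carbon. Within the data shown here, no measured step changes a substituent in this way, so the measured steps give no direct guide, and no step beyond the scatter is expected. Compound 4 is therefore estimated at 90%, between 70% and 100%, an expected step of a number 5 percentage points lower from compound 3 to compound 4 (within the scatter).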

Compound 4, a percentage reported as activity, at one concentration (the size of the read-out at that concentration, not a potency): 97%
Compound 4: middle estimate off by 7 percentage points, on the low side; the range from low to high includes it.
By their numbers in this assay, from the lowest: compound 2; then compounds 3, 4 and 1 (each within the scatter of the next).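

In this assay, putting fluoro in place of isopropyl on this aromatic carbon, meta to a large group, gives a number 2 percentage points higher from compound 3 to compound 4 (within the scatter). Swapping the larger group for a single fluorine atom therefore leaves the read-out unmoved here, whereas the only earlier step changed configuration, not a substituent. Nothing known here explains this lack of change.

Still open, going by these compounds, is whether fluoro would keep the gap seen between compound 2 and compound 3 if the stereocentre were drawn the other way. On these data alone, it is also open whether an amine or a carboxylic acid at this position would shift the number.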